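Cytotoxicity notes on a triazinylthioacetamide series

A few compounds are considered here, and "the series" means these few. Any claim that something is new, unique, unknown or untested is made for them only; others in the source may bear on it.

Measured so far:
- compound 1 `COC(=O)c1sccc1NC(=O)CSc1nncnc1-c1ccccc1Cl`: 105000 nM
- compound 2 `O=C(CSc1nncnc1-c1cccc2ccccc12)Nc1ccccc1[N+](=O)[O-]`: 142000 nM

In an ADME assay on MT4 cells (Homo sapiens) for cytotoxicity, read by MTT assay (on this read-out higher numbers stand for lower toxicity in this test and lower numbers for higher toxicity in this test), compound 1 gives 105000 nM. In this assay compound 2 gives 142000 nM. The two numbers lie within the usual scatter of each other, so neither compound can be set apart from the other on this read-out; both show only weak toxicity toward the cells.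

Compound 3 `Cc1ccc(NC(=O)CSc2nncnc2-c2ccccc2Cl)c(Br)c1` has not been measured in this assay. It differs from compound 1 in one place: 2-bromo-4-methylphenyl in place of 2-(methoxycarbonyl)thiophen-3-yl on an amide-type nitrogen. For the measured compounds named here, no step between measured compounds is available to calibrate a change of this kind, and compound 2 changes two parts of the molecule at once relative to compound 1, so it gives no direct guide.

On what is known, a step from compound 1 to compound 3 of about a 1.2-fold lower number from compound 1 to compound 3 (0.07 log units; within the scatter) is expected, that is, no change beyond the scatter in either direction. Compound 3 is therefore estimated at 90000 nM, with a range from 35000 nM to 250000 nM.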

Compound 3, half-maximal cytotoxic concentration: 45000 nM
Beside the measured number, compound 3's estimate is 2.0-fold (0.30 log units) above it, and the stated range covers the measured number.
By their numbers in this assay, from the lowest: compound 3; then compounds 1 and 2 (each within the scatter of the next).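

In this assay the group on the amide-type nitrogen is now shown to matter: 2-bromo-4-methylphenyl in place of 2-(methoxycarbonyl)thiophen-3-yl gives a 2.3-fold lower number from compound 1 to compound 3 (0.37 log units; beyond the scatter), the first single-place change in the series that can be read, and one that goes beyond the scatter. The direction is toward higher toxicity in this test, although the step is modest, so this position can shift the read-out with the rest of the molecule held constant. The change replaces a five-membered aromatic ring carrying an ester with a carbon-only six-membered aromatic ring carrying bromine and methyl, and no information is available on why the number moves.

For the compounds shown here, the single step does not separate the contributions of the ring, the bromine, the methyl and the methoxycarbonyl, and a plain phenyl, a phenyl carrying only the bromine or a thiophene carrying a carboxylic acid would each bear on that question. As far as these compounds go, it also remains open whether 2-bromo-4-methylphenyl would give a similar step on the core of compound 2, which carries a different group on the shared core.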